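Compound 3 against compound 1: working notes

This account rests on a few compounds, and the source may have more. Where it says the series, first, only, none or still open, it means among the compounds named here.

Measured in an ADME assay on L02 cells (Homo sapiens) for cytotoxicity, read by MTT assay, with a stated time of 48 h; a higher number here means a weaker inhibitor, a lower number a stronger inhibitor:
- compound 1 `CCn1c(C(=O)NCCCN(C)C)ccc1C(CC)(CC)c1ccc(OCC(=O)C(C)(C)C)c(C)c1`: 670 nM
- compound 2 `CCn1c(C(=O)NCCN)ccc1C(CC)(CC)c1ccc(OCC(=O)C(C)(C)C)c(C)c1`: 2500 nM

For the measured compounds named here, compound 1 holds the lower of the two numbers in this assay, and compound 2 is its only neighbour. Going by the values given here, the single measured step, a 3.7-fold higher number from compound 1 to compound 2 (0.57 log units; beyond the scatter), is modest and falls on the amide side chain, two bonds along the chain from an amide-type nitrogen.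

Compound 3 `CCn1c(C(=O)NCCCN(C)C)ccc1C(CC)(CC)c1ccc(OCC(O)C(C)(C)C)c(C)c1` keeps that side chain of compound 1 and differs elsewhere: 1-hydroxy-2,2-dimethylpropyl in place of (tert-butyl)carbonyl on a saturated chain carbon bound to an oxygen on an aromatic ring. In words, 1-hydroxy-2,2-dimethylpropyl stands in place of (tert-butyl)carbonyl on a saturated chain carbon bound to an oxygen on an aromatic ring.

Among the compounds with values here, no measured step touches this place, so the data offer no direct guide. The step of a 3.7-fold higher number from compound 1 to compound 2 (0.57 log units; beyond the scatter) serves only as a rough gauge of how far one change has moved the number in this small set. A smaller move is expected here, leaning towards a higher number, and no move beyond the scatter remains quite possible. The expected step is a 1.4-fold higher number from compound 1 to compound 3 (0.15 log units; within the scatter). Compound 3 is estimated at 950 nM, with an expected range of 400 nM to 2300 nM.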

Compound 3, half-maximal inhibitory concentration: 470 nM
Estimate against measurement, compound 3: 2.0-fold (0.31 log units) above; measured number inside the range.
By their numbers in this assay, from the lowest: compounds 3 and 1 (each within the scatter of the next); then compound 2.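

At this position, in this assay, the first step available is a 1.4-fold lower number from compound 1 to compound 3 (0.15 log units; within the scatter), so 1-hydroxy-2,2-dimethylpropyl and (tert-butyl)carbonyl on a saturated chain carbon bound to an oxygen on an aromatic ring cannot be told apart by this read-out. For the compounds shown here, the exchange keeps the count of 6 heavy atoms and replaces a group with 0 hydrogen-bond donors by one with 1 hydrogen-bond donor, and in this set that difference comes with numbers that lie within the scatter of each other, whereas the one step on the amide side chain, a 3.7-fold higher number from compound 1 to compound 2 (0.57 log units; beyond the scatter), lies beyond it. Nothing available gives a cause for this result.

Still open, as far as these compounds go, is whether other groups at this place, such as a carboxylic acid, an amine or a longer chain in place of the (tert-butyl)carbonyl, would also stay within the scatter of compound 1. Also open, from the compounds shown here alone, is how the 1-hydroxy-2,2-dimethylpropyl group behaves when paired with the side chain of compound 2.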